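The source may report more compounds than this note shows. Statements on the series, on what has been measured and on what is new or still open speak of the compounds shown alone.

Compound 3 `COc1cc(Cl)cc(-c2nn(-c3cccc(NC(=O)c4cccc(C(F)(F)F)c4)c3)cc2-c2ccncc2)c1`: 29.1%
Compound 1 `COc1cc(Cl)cc(-c2nn(-c3cccc(NC(=O)Nc4ccc(Cl)c(C(F)(F)F)c4)c3)cc2-c2ccncc2)c1`: -27.5%
Compound 2 `COc1cc(Cl)cc(-c2nn(-c3cccc(NC(=O)Nc4ccc(Cl)c(Cl)c4)c3)cc2-c2ccncc2)c1`: -18.5%

In a functional assay on SR cells (Homo sapiens) for inhibition, read by sulforhodamine B assay, with a stated time of 48 h, tested at 10 uM (a higher number here means a weaker effect of the compound at the concentration tested, a lower number a stronger effect), compound 3 stands highest of the three measured values: the steps of a number 56.6 percentage points higher from compound 1 to compound 3 (beyond the scatter) and a number 47.6 percentage points higher from compound 2 to compound 3 (beyond the scatter) are both large and beyond the scatter, whereas the step of a number 9 percentage points higher from compound 1 to compound 2 (within the scatter) lies within the scatter. Compound 4 `COc1cc(Cl)cc(-c2nn(-c3cccc(NC(=O)c4cc(C(F)(F)F)cc(C(F)(F)F)c4)c3)cc2-c2ccncc2)c1` differs from compound 3 by trifluoromethyl in place of hydrogen on an aromatic carbon. Within the data shown here, no measured step exchanges hydrogen for trifluoromethyl; the one step involving a trifluoromethyl group, a number 9 percentage points higher from compound 1 to compound 2 (within the scatter), is within the scatter, so only a small shift, in no clear direction, is expected. The expected step is a number 3.1 percentage points lower from compound 3 to compound 4 (within the scatter), within the scatter. For compound 4 the estimated value is 26%, with an expected range from 2% to 50%.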

Compound 4, a percentage reported as activity, at one concentration (the size of the read-out at that concentration, not a potency): 41%
Compound 4: the middle estimate sits 15 percentage points below what was measured; measured number inside the range.
By their numbers in this assay, from the lowest: compounds 1 and 2 (each within the scatter of the next); then compound 3; then compound 4.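

In this assay, trifluoromethyl on this aromatic carbon, meta to a large group and meta to a trifluoromethyl group, gives a number 11.9 percentage points higher from compound 3 to compound 4 (beyond the scatter). The step is modest, but it goes toward a weaker effect, so this position is not silent to substitution. No available data bear on the reason for this shift.

Still open, as far as these compounds go, is whether a smaller group here, such as fluorine or methyl, or a polar one, such as an amine or a carboxylic acid, moves the value the same way. Also open, from the compounds shown here alone, is whether this shift carries over to the urea compounds.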